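Replacing an acetamidophenyl with a pyridyl on the triazole

A few compounds are considered here, and "the series" means these few. Any claim that something is new, unique, unknown or untested is made for them only; others in the source may bear on it.

Compound 1, `Nc1ccc(-c2cn(Cc3cc(C(=O)O)cc(-c4ccccc4C(=O)O)c3)nn2)cc1`, gives 80500 nM in an assay on cells for inhibition of ubiquitin carboxyl-terminal hydrolase isozyme L5 (Homo sapiens), read by fluorescence, with a stated time of 30 min; a lower number here means a stronger inhibitor, a higher number a weaker inhibitor.
Compound 2, `CC(=O)Nc1ccc(-c2cn(Cc3cc(C(=O)O)cc(-c4ccccc4C(=O)O)c3)nn2)cc1`, gives 80900 nM in this assay.

Compound 2 and compound 1 sit at the same level: the step of a 1.0-fold higher number from compound 1 to compound 2 (0.00 log units; within the scatter) lies within the scatter, so the two numbers cannot be told apart. That step changed only the group on the nitrogen that hangs from the phenyl ring, from hydrogen to acetyl, and it changed nothing measurable.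

Compound 3, `O=C(O)c1cc(Cn2cc(-c3cccnc3)nn2)cc(-c2ccccc2C(=O)O)c1`, goes further and exchanges that whole aromatic group: pyridin-3-yl in place of 4-acetamidophenyl on an aromatic carbon. Going by the values given here, no measured step swaps one aromatic ring for another at this place; the only step on record, a 1.0-fold higher number from compound 1 to compound 2 (0.00 log units; within the scatter), touched the ring that now leaves and bears on the new change only loosely. With that step showing no movement, no step beyond the scatter is expected from compound 2 to compound 3, that is a 1.0-fold lower number from compound 2 to compound 3 (0.00 log units; within the scatter). Compound 3 is therefore expected to give about 80000 nM in this assay. The expected range for compound 3 runs from 30000 nM to 200000 nM.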

Compound 3, half-maximal inhibitory concentration: 252000 nM
Compound 3: middle estimate off by 3.2-fold (0.50 log units), on the low side, outside the stated range (above it).
By their numbers in this assay, from the lowest: compounds 1 and 2 (each within the scatter of the next); then compound 3.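

Exchanging the whole aromatic group registers in this assay where the change on the nitrogen did not: pyridin-3-yl in place of 4-acetamidophenyl gives a 3.1-fold higher number from compound 2 to compound 3 (0.49 log units; beyond the scatter), and pyridin-3-yl in place of 4-aminophenyl gives a 3.1-fold higher number from compound 1 to compound 3 (0.50 log units; beyond the scatter). Both steps are modest but beyond the scatter and point towards weaker inhibition, so this aromatic carbon of the five-membered ring is not indifferent to the group it carries, even though the group on the phenyl nitrogen made no measurable difference. The change does two things at once, however: the six-membered ring gains a hetero atom, and the group falls from 10 heavy atoms to 6 in the step from compound 2, so neither alteration can be singled out as the one that matters.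

No evidence on hand accounts for this loss of inhibition.

A plain phenyl at this position would separate the effect of the ring nitrogen from that of the missing substituent on the ring. A pyridin-3-yl bearing an amine would test whether a substituent on the new ring can restore the level of compound 1 and compound 2.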